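Swapping a ring on the amide of a shared core

The compounds below may be only part of what the source reports. "The series", "measured", "known", "first", "only" and "open" are said of these compounds alone.

Compound 1, `COc1ccc(-c2cnc(NC(=O)c3ccccn3)n2C)cc1`, gives in a toxicity assay on THP-1 cells (Homo sapiens) for inhibition (a higher number here means that more compound is tolerated, a lower number that less compound is tolerated), only a limit of the assay, > 100000 nM.
Compound 2, `CCC(=O)Nc1ncc(-c2ccc(OC)cc2)n1C`, gives in this assay only a limit of the assay, > 100000 nM.
Compound 3, `COc1ccc(-c2cnc(NC(=O)c3ccc(C)cc3)n2C)cc1`, gives in this assay only a limit of the assay, > 100000 nM.

All three measured compounds share one core and differ only in the group attached to the carbonyl carbon of the amide. Among the measured compounds shown here, compound 3 therefore stands where the others stand: at a limit, not at a number, and the limit of > 100000 nM in this assay, at which 3 of the 3 values shown sit, shows that no measured compound falls away from it.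

Compound 4, `COc1ccc(-c2cnc(NC(=O)c3ccccc3O)n2C)cc1`, keeps that core and differs from compound 3 in one place: 2-hydroxyphenyl in place of 4-methylphenyl on a carbonyl carbon.

For the measured compounds named here, the steps that bear on this change all concern the same position. The step that the two limits leave unreadable from compound 1 to compound 3 and the step that the two limits leave unreadable from compound 2 to compound 3 cannot be read in size, and neither can a step that the two limits leave unreadable from compound 1 to compound 2, since both ends of each sit at the limit. Three rather different groups on the carbonyl carbon have thus left this assay unchanged as far as the assay can tell, so no step beyond the scatter in either direction is expected for the 2-hydroxyphenyl.

Compound 4 is expected to give 100000 nM in this assay, within 50000 nM to 200000 nM, most likely again as a limit. The expected step is a number no higher from compound 3 to compound 4 (the limit leaves the size open).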

Compound 4, half-maximal cytotoxic concentration: > 100000 nM
Compound 4 gave a limit, no number (the forecaster's own chance of this, stated with the estimate: 85%); the middle value lies on the limit itself.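

Compound 4 stays at a limit, as compounds 1, 2 and 3 do, so none of the steps from those three compounds to compound 4 can be read in size in this assay: the limit of > 100000 nM in this assay, at which 4 of the 4 values shown sit.

The compounds shown leave open how much of each is needed to reach a real number in this assay and whether any group on the carbonyl carbon changes that amount.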